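This account rests on a few compounds, and the source may have more. Where it says the series, first, only, none or still open, it means among the compounds named here.

Measured compounds:
compound 1 `CNC(=O)c1cc(Oc2ccc(C(=O)/C=C/c3cccc(Br)c3)cc2)ccn1` gives 3400 nM
compound 2 `CNC(=O)c1cc(Oc2ccc(C(=O)/C=C/c3ccc(F)cc3Cl)cc2)ccn1` gives 4760 nM

In a functional assay on PC-3 cells (Homo sapiens) for cytotoxicity, read by MTT assay, with a stated time of 72 h (a higher number here means a weaker inhibitor, a lower number a stronger inhibitor), compound 1 gives 3400 nM, the lowest of the two numbers shown, while compound 2 gives 4760 nM, a value that lies within the scatter of compound 1, so no order between the two can be read. For the measured compounds named here, the single measured step, a 1.4-fold higher number from compound 1 to compound 2 (0.15 log units; within the scatter), shows that exchanging one substituted phenyl for another on the double-bonded chain carbon left the number essentially where it was.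

Compound 3 `CNC(=O)c1cc(Oc2ccc(C(=O)/C=C/c3ccc(OC)cc3)cc2)ccn1` has not yet been measured. Relative to compound 1 it carries 4-methoxyphenyl in place of 3-bromophenyl on a double-bonded chain carbon bound to a double-bonded chain carbon. Going by the values given here, no measured step involves a 4-methoxyphenyl group, so the only guidance is the step from compound 1 to compound 2, which stayed within the scatter. Compound 3 is therefore expected to show a step of no change at the digits printed from compound 1 to compound 3 (within the scatter), nothing beyond the scatter. Compound 3 is estimated at 3400 nM, with a range from 1500 nM to 8000 nM.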

Compound 3, half-maximal inhibitory concentration: > 50000 nM
Compound 3: only a limit was reported; the forecaster's own chance of this, stated with the estimate: 5%; middle value at least 14-fold (1.16 log units) from the limit.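

In this assay, the result for compound 3 is a limit and not a number: the limit of > 50000 nM in this assay, at which 1 of the 3 values shown sits.

Even so, the place on a double-bonded chain carbon bound to a double-bonded chain carbon proves sensitive to the group it carries, since 4-methoxyphenyl brings an at least 14-fold higher number from compound 1 to compound 3 (1.16 log units; beyond the scatter) and an at least 10-fold higher number from compound 2 to compound 3 (1.02 log units; beyond the scatter), both large. The earlier exchange of 3-bromophenyl for 2-chloro-4-fluorophenyl stayed within the scatter (a 1.4-fold higher number from compound 1 to compound 2 (0.15 log units; within the scatter)), so that step alone had hidden that not every substituted phenyl is equivalent here.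

The compounds shown cannot separate the effect of the methoxy group from that of where it sits on the ring, nor say how far compound 3 lies past its limit. A 3-methoxyphenyl, a 4-bromophenyl or an unsubstituted phenyl group at this place would bear on both the group and its ring position.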